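This account rests on a few compounds, and the source may have more. Where it says the series, first, only, none or still open, it means among the compounds named here.

Measured compounds:
compound 1, `COc1ccc(C23CCC(=O)N2CCCO3)cc1`, < 150 mg/kg
compound 2, `Cc1ccc(C23CCC(=O)N2CCCO3)cc1`, < 50 mg/kg
compound 3, `COc1ccc(C(=O)CCC(=O)NCCCO)cc1`, 150 mg/kg

In a functional assay on the whole organism (Central nervous system) for activation, with Mus musculus as the target (a higher number here means that more compound is needed for the effect, a lower number that less compound is needed), compound 1 gives < 150 mg/kg, which is a limit of the assay and not a number. In this assay compound 2 likewise gives < 50 mg/kg, again a limit. For the measured compounds named here, compound 3 is the one compound with a read number here, 150 mg/kg in this assay. The change from compound 1 to compound 2 is methyl in place of methoxy on an aromatic carbon, and its step, a step that the two limits leave unreadable from compound 1 to compound 2, cannot be read because both values are limits, the limit of < 150 mg/kg in this assay, at which 1 of the 3 values shown sits, and (the limit of < 50 mg/kg in this assay, at which 1 of the 3 values shown sits). Compound 4, `Cc1ccc(C(=O)CCC(=O)NCCCO)cc1`, carries the same kind of change against compound 3: methyl in place of methoxy on an aromatic carbon. The difference between the core of compound 3 and the core of compound 1 is not broken down here. Going by the values given here, the only measured instance of this change, that from compound 1 to compound 2, sits between two limits and gives no readable size. The step from compound 3 to compound 4 is expected to be small, a 1.4-fold lower number from compound 3 to compound 4 (0.13 log units; within the scatter), resting only on compound 3 at 150 mg/kg. Compound 4 is therefore estimated at 110 mg/kg in this assay, with a range from 40 mg/kg to 300 mg/kg.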

Compound 4, dose for half-maximal effect: 300 mg/kg
Beside the measured number, compound 4's estimate is 2.7-fold (0.44 log units) below it; the range from low to high includes it.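

In this assay, methyl in place of methoxy on an aromatic carbon gives a 2.0-fold higher number from compound 3 to compound 4 (0.30 log units; within the scatter), so on this one core the change stays within the usual scatter of repeated measurements and shows no clear effect. On the core of compound 1, the value of compound 1 is a limit of the assay and not a number: the limit of < 150 mg/kg in this assay, at which 1 of the 4 values shown sits. Compound 2 likewise carries a limit and not a number, so the step on that core cannot be read, and whether the change behaves alike on the two cores is not shown: the limit of < 50 mg/kg in this assay, at which 1 of the 4 values shown sits.

The compounds shown leave open how the number would move with a different group on the same aromatic carbon, such as a chlorine atom or a dimethylamino group, or with a longer chain on the amide nitrogen. They also leave open what size the change has on the core of compound 1, which would take read numbers for both compound 1 and compound 2.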